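A methoxy for a fluoro in a level series

This account rests on a few compounds, and the source may have more. Where it says the series, first, only, none or still open, it means among the compounds named here.

Of the compounds shown here, three that share one core have been measured in a functional assay on DU-145 cells (Homo sapiens) for inhibition, read by trypan blue exclusion, with a stated time of 96 h (a lower number here means a stronger inhibitor of growth, a higher number a weaker inhibitor of growth), so far. Compound 1 (`O=C(/C(=C\c1ccc(Br)c(O)c1)Sc1ccc(Br)cc1)c1ccc(Br)cc1`) carries a 4-bromo-3-hydroxyphenyl group and gives 1000 nM as its value. Compound 2 (`O=C(/C(=C\c1c[nH]c2ccccc12)Sc1ccc(Br)cc1)c1ccc(Br)cc1`) has 1H-indol-3-yl at that place and gives 1000 nM as its value. Compound 3 (`O=C(/C(=C\c1ccc(F)cc1F)Sc1ccc(Br)cc1)c1ccc(Br)cc1`) has 2,4-difluorophenyl there and gives 1000 nM as its value, which stands level with the other two.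

Compound 4 (`COc1ccc(/C=C(/Sc2ccc(Br)cc2)C(=O)c2ccc(Br)cc2)c(F)c1`) departs from compound 3 at one point, with methoxy in place of fluoro on an aromatic carbon, para to a large group: methoxy in place of fluoro on an aromatic carbon is the whole difference, and it turns 2,4-difluorophenyl into 2-fluoro-4-methoxyphenyl.

Among the compounds with values here, no measured step makes this exact exchange. The nearest evidence comes from replacing the entire group at this place, which gave no change at the digits printed from compound 1 to compound 3 (within the scatter) and no change at the digits printed from compound 2 to compound 3 (within the scatter) and also no change at the digits printed from compound 1 to compound 2 (within the scatter) in the remaining pair. With all three steps of that size, no step beyond the scatter is expected in this assay here. The expected step is no change at the digits printed from compound 3 to compound 4 (within the scatter) on this estimate. Compound 4 is estimated at 1000 nM with an expected range from 400 nM to 2500 nM as its likely span.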

Compound 4, concentration for 50% growth inhibition: 20000 nM
Compound 4: middle estimate off by 20-fold (1.30 log units), on the low side; the measured number lies above the stated range.
By their numbers in this assay, from the lowest: compounds 1, 2 and 3 (each within the scatter of the next); then compound 4.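

In this assay this position turned out not to be indifferent to what it carries: three quite different groups had stood level, yet methoxy in place of fluoro on an aromatic carbon, para to a large group, gave a 20-fold higher number from compound 3 to compound 4 (1.30 log units; beyond the scatter) and so made compound 4 the weaker inhibitor of growth. The comparisons of whole groups agree, with a 20-fold higher number from compound 2 to compound 4 (1.30 log units; beyond the scatter) and with a 20-fold higher number from compound 1 to compound 4 (1.30 log units; beyond the scatter) as well, which sets 2-fluoro-4-methoxyphenyl apart from all three earlier groups and shows that their level values were no sign of a place that accepts any group. Nothing in the information at hand accounts for this step.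

As far as these compounds go, it remains open whether a hydroxy group, an amino group or a longer ethoxy chain at this same place would stand with compounds 1, 2 and 3 or with compound 4. It is also open whether methoxy would give a step of this size on a phenyl ring without the remaining fluoro, as the compounds shown hold only this single instance of the exchange.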